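Chloro at the benzyl ring of benzimidazole acylthioureas and acylureas

A few compounds are considered here, and "the series" means these few. Any claim that something is new, unique, unknown or untested is made for them only; others in the source may bear on it.

Measured compounds in a functional assay on SW-620 cells (Homo sapiens) for inhibition, read by MTT assay, with a stated time of 48 h; on this read-out lower numbers stand for stronger inhibition and higher numbers for weaker inhibition:
compound 1 `Cc1ccc(NC(=S)NC(=O)c2ccc(OCc3ccccc3Cl)cc2)cc1-c1nc2ccccc2[nH]1`, 57100 nM
compound 2 `Cc1ccc(NC(=S)NC(=O)c2ccc(OCc3ccc(Cl)cc3Cl)cc2)cc1-c1nc2ccccc2[nH]1`, 57200 nM
compound 3 `Cc1ccc(NC(=O)NC(=O)c2ccc(OCc3ccccc3)cc2)cc1-c1nc2ccccc2[nH]1`, 30100 nM

Compound 2 differs from compound 1 by chloro in place of hydrogen on an aromatic carbon. That change gave a 1.0-fold higher number from compound 1 to compound 2 (0.00 log units; within the scatter). The difference between the core of compound 1 and the core of compound 3 is not broken down here; the values of compound 3 and compound 1 lie within the scatter of each other.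

Compound 4 `Cc1ccc(NC(=O)NC(=O)c2ccc(OCc3cccc(Cl)c3)cc2)cc1-c1nc2ccccc2[nH]1` is not yet measured; it differs from compound 3 by chloro in place of hydrogen on an aromatic carbon. This is the same kind of change as in compound 2, yet the surroundings differ: in compound 2 the chloro enters meta to a chloro group and para to a large group, whereas in compound 4 it enters meta to a large group.

Because a 1.0-fold higher number from compound 1 to compound 2 (0.00 log units; within the scatter), compound 4 is expected to stay close to compound 3, with an estimated step of a 1.0-fold lower number from compound 3 to compound 4 (0.00 log units; within the scatter). Compound 4 is thus estimated at 30000 nM, with an expected range from 12000 nM to 75000 nM.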

Compound 4, half-maximal inhibitory concentration: 16000 nM
Compound 4: middle estimate off by 1.9-fold (0.27 log units), on the high side; measured number inside the range.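

In this assay, chloro in place of hydrogen gave a 1.9-fold lower number from compound 3 to compound 4 (0.27 log units; within the scatter) on the benzyl ring of the core of compound 3. Set beside the earlier step, the change carries across the two cores without a measurable difference: the same change on two cores in this assay, a 1.0-fold higher number (0.00 log units; within the scatter) from compound 1 to compound 2 and a 1.9-fold lower number (0.27 log units; within the scatter) from compound 3 to compound 4, 1.9-fold (0.28 log units) apart, within the scatter of two such steps

Within the data shown here, this shows only that neither step, on either core, stands clear of the scatter; it does not show that chloro has no effect or the same effect on both cores, since the two pairs also place the chloro differently on the ring.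

On these data alone, it remains open whether 3-chlorobenzyl would read the same on the core of compound 1. As far as these compounds go, it also remains open whether an amine, a carboxylic acid or a methoxy group at that place would move the number beyond the scatter.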